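The compounds below may be only part of what the source reports. "The series", "measured", "known", "first", "only" and "open" are said of these compounds alone.

In a functional assay on cells (Homo sapiens) for cytotoxicity, read by MTT assay, with a stated time of 48 h (on this read-out higher numbers stand for weaker inhibition and lower numbers for stronger inhibition), compound 1 `O=c1c(-c2cc(O)cc(O)c2)cnc2ccccn12` gives 3000 nM, compound 2 `O=c1cc(-c2ccc(Cl)cc2)nc2ccccn12` gives 2300 nM and compound 3 `O=c1c(-c2ccccc2)cnc2c(OCc3ccccc3)cccn12` gives 3000 nM. Compound 2 therefore stands within the scatter of both other compounds. Compound 4 `O=Cc1ccc(-c2cc(=O)n3ccccc3n2)cc1` keeps the core of compound 2 but has formyl in place of chloro on an aromatic carbon, para to a large group: formyl in place of chloro on an aromatic carbon. For the measured compounds named here, no measured pair shows what a single change does in this assay. Going by the values given here, the only guide is compound 2 at 2300 nM, so no step beyond the scatter is expected in either direction. The estimated step of a 1.3-fold higher number from compound 2 to compound 4 (0.12 log units; within the scatter) stays within the scatter. For compound 4 the expected value is 3000 nM, with an estimated range from 1000 nM to 9000 nM.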

Compound 4, half-maximal inhibitory concentration: 2500 nM
Compound 4: middle estimate off by 1.2-fold (0.08 log units), on the high side, within the range that was stated.
By their numbers in this assay, from the lowest: compounds 2, 4, 1 and 3 (each within the scatter of the next).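

In this assay this pair is the first single change among these compounds, and it gives a 1.1-fold higher number from compound 2 to compound 4 (0.04 log units; within the scatter) with formyl in place of chloro on an aromatic carbon, para to a large group. At this position, then, the assay does not separate the two groups, although formyl brings a hydrogen-bond acceptor that chloro lacks. No measurement shown here accounts for this result.

Going by these compounds, whether an amine, a carboxylic acid or a longer chain at this position would also stay within the scatter remains open. So does whether formyl in place of chloro would behave alike elsewhere on the shared core.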